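Shortening the hydroxamate chain by one carbon

This account rests on a few compounds, and the source may have more. Where it says the series, first, only, none or still open, it means among the compounds named here.

Measured so far in a functional assay on U-251 cells (Homo sapiens) for inhibition, read by MTT assay, with a stated time of 48 h; a higher number here means a weaker inhibitor, a lower number a stronger inhibitor:
compound 1 `C#CCN(C)CCCOc1cc(NCc2ccc(/C=C/C(=O)NO)cc2)ccc1Cl` gives 990 nM
compound 2 `C#CCN(C)CCCOc1cc(NC(=O)CCCCCCCC(=O)NO)ccc1Cl` gives 4780 nM
compound 3 `C#CCN(C)CCCOc1ccc(NC(=O)CCCCCCC(=O)NO)cc1Cl` gives 2730 nM

Compound 2 cannot be told apart from compound 3 here, since their two numbers lie within the usual scatter of each other. Compound 1 has a clearly lower number than compound 2, a gap beyond the scatter, so compound 2 stands in the weaker part of this small set.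

The next molecule is compound 4 `C#CCN(C)CCCOc1cc(NC(=O)CCCCCCC(=O)NO)ccc1Cl`, which differs from compound 2 in one place: hydroxycarbamoyl in place of (hydroxycarbamoyl)methyl on a saturated chain carbon, six bonds along the chain from a carbonyl carbon on a saturated chain carbon, six bonds along the chain from a carbonyl carbon. The chain simply ends one unit sooner.

Going by the values given here, no measured pair shows this change on its own, so its size has to be judged indirectly. Compound 3 carries the shorter chain too, on a differently substituted core, and its value of 2730 nM gives the best available guide. The expected 1.4-fold lower number from compound 2 to compound 4 (0.16 log units; within the scatter) is a modest move towards a lower number, within the scatter.

The estimate for compound 4 is 3300 nM, with the measurement expected between 1400 nM and 7500 nM in this assay.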

Compound 4, half-maximal inhibitory concentration: 600 nM
For compound 4 the middle estimate is 5.5-fold (0.74 log units) above the measured one; the measured number lies below the stated range.
By their numbers in this assay, from the lowest: compounds 4 and 1 (each within the scatter of the next); then compounds 3 and 2 (each within the scatter of the next).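

In this assay, going by these compounds alone, ending the chain one unit sooner, with hydroxycarbamoyl in place of (hydroxycarbamoyl)methyl, gives an 8.0-fold lower number from compound 2 to compound 4 (0.90 log units; beyond the scatter), and this is the first change in the set that can be read on its own. The two compounds share everything except that one chain unit, so the chain length at this place, six bonds along the chain from a carbonyl carbon, clearly matters in this cell assay, and a small edit at the chain end is enough to move the number past the usual variation between repeat measurements. Nothing available here gives a reason for the size of this step.

From the compounds shown here alone, two chain lengths make a single step and not a trend, so it remains open whether a still shorter chain, ending in a group such as a carboxylic acid or keeping the hydroxycarbamoyl end, would lower the number further or raise it again. Within the data shown here, it is also open whether the same shortening would have a similar effect on the other cores in this set, where no matched pair yet isolates chain length.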